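This account rests on a few compounds, and the source may have more. Where it says the series, first, only, none or still open, it means among the compounds named here.

Compound 1, `CN1CCC[C@@H]1Cn1nc(Cc2cccc(Cl)c2)c2ccccc2c1=O`: 631 nM
Compound 2, `CN1CCC[C@@H]1Cn1nc(CC2CCCCC2)c2ccccc2c1=O`: > 1990 nM
Compound 3, `CN1CCC[C@@H]1Cn1nc(CCc2ccccc2)c2ccccc2c1=O`: 200 nM

Three compounds sharing one core have been characterised in an assay for binding affinity to Alpha-1B adrenergic receptor (Homo sapiens); on this read-out lower numbers stand for stronger inhibition and higher numbers for weaker inhibition. Compound 1 gives 631 nM in this assay, and compound 3 gives 200 nM. For compound 2 the readout in this assay is a limit rather than a number, > 1990 nM; this is the limit of > 1990 nM in this assay, at which 1 of the 3 values shown sits.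

Compound 3 stands lowest of the two numbers shown, with compound 1 nearest, the step being a 3.2-fold lower number from compound 1 to compound 3 (0.50 log units; beyond the scatter). The step of an at least 3.1-fold higher number from compound 1 to compound 2 (0.49 log units; beyond the scatter) and the step of an at least 9.9-fold lower number from compound 2 to compound 3 (0.99 log units; beyond the scatter) both set compound 2 at the weak end of the series.

The unmeasured compound 4, `CN1CCC[C@@H]1Cn1nc(Cc2cccc(F)c2)c2ccccc2c1=O`, differs from compound 3 by 3-fluorophenyl in place of benzyl on a saturated chain carbon bound to an aromatic carbon. The step that bears most directly on this change is a 3.2-fold lower number from compound 1 to compound 3 (0.50 log units; beyond the scatter), where benzyl in place of 3-chlorophenyl gave a modestly lower number; compound 4 runs that change the other way, toward a 3-fluorophenyl group. Compound 4 is therefore expected to sit somewhat above compound 3, a step of a 2.0-fold higher number from compound 3 to compound 4 (0.30 log units; within the scatter), smaller than the reverse step seen between compound 1 and compound 3. Compound 4 is estimated at 400 nM, with a range of 160 nM to 1000 nM.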

Compound 4, inhibition constant: 398 nM
Compound 4: the middle estimate sits 1.0-fold (0.00 log units) above what was measured, within the range that was stated.
By their numbers in this assay, from the lowest: compounds 3, 4 and 1 (each within the scatter of the next, the first and the last beyond it). At a limit, above all of these: compound 2.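

Both steps that link compound 4 to its closest neighbours stay within the scatter in this assay: a 1.6-fold lower number from compound 1 to compound 4 (0.20 log units; within the scatter) for fluoro in place of chloro on an aromatic carbon, and a 2.0-fold higher number from compound 3 to compound 4 (0.30 log units; within the scatter) for 3-fluorophenyl in place of benzyl. Compound 4 thus sits within the scatter of two compounds that lie beyond the scatter of each other, so on these values the exchange of chloro for fluoro does not resolve at this position, and the change from phenethyl to 3-fluorobenzyl only just stays inside the scatter. The 3-fluorophenyl group also remains clearly apart from cyclohexyl, with an at least 5.0-fold lower number from compound 2 to compound 4 (0.69 log units; beyond the scatter), which gives a second aromatic group on this chain carbon that stands apart from the saturated ring, though that comparison has only one firm end, as compound 2 is held at a limit and not a number: the limit of > 1990 nM in this assay, at which 1 of the 4 values shown sits.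

What the compounds leave open is whether a methoxy or trifluoromethyl group in place of the fluoro would fall within the same narrow band. On these data alone, it is also open how a longer chain than phenethyl, or an amine on the chain, would read in this assay.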